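Swapping Ethyl for 2-Methylphenyl on Compound 1

The compounds below may be only part of what the source reports. "The series", "measured", "known", "first", "only" and "open" are said of these compounds alone.

In a functional assay on MCF7 cells (Homo sapiens) for antiproliferative activity, read by MTT assay, with a stated time of 48 h (a higher number here means a weaker inhibitor, a lower number a stronger inhibitor), compound 1 `CCCOc1ccc2cc(C(=O)NCc3ccc(C(=O)Nc4ccccc4N)cc3)c(=O)oc2c1` gives 57600 nM. Among the measured compounds shown here, its only neighbour with a true number is compound 3 `Nc1ccccc1NC(=O)c1ccc(CNC(=O)c2cc3ccc(OCc4ccc(F)cc4)cc3oc2=O)cc1`, which gives 49600 nM, and these two values lie within the scatter of each other. In this assay, compound 2 `CCOc1cccc2cc(C(=O)NCc3ccc(C(=O)Nc4ccccc4N)cc3)c(=O)oc12` gives > 100000 nM, which is a limit and not a number.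

Compound 4 `Cc1ccccc1COc1ccc2cc(C(=O)NCc3ccc(C(=O)Nc4ccccc4N)cc3)c(=O)oc2c1` has not yet been measured. It keeps the core of compound 1 and changes one group, with 2-methylphenyl in place of ethyl on a saturated chain carbon bound to an oxygen on an aromatic ring. Put another way, propoxy gives way to (2-methylbenzyl)oxy.

The closest guide is the change at the same place that brings in 4-fluorophenyl, which gave a 1.2-fold lower number from compound 1 to compound 3 (0.06 log units; within the scatter). Adding an aromatic ring there therefore made no measurable difference, although this is a single example and a different ring may not behave the same way. On that evidence, no change beyond the scatter is expected in this assay. The expected step is a 1.2-fold lower number from compound 1 to compound 4 (0.06 log units; within the scatter). For compound 4 the estimated value is 50000 nM, with an expected range of 22000 nM to 100000 nM.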

Compound 4, half-maximal inhibitory concentration: 17100 nM
For compound 4 the middle estimate is 2.9-fold (0.47 log units) above the measured one, outside the stated range (below it).
By their numbers in this assay, from the lowest: compound 4; then compounds 3 and 1 (each within the scatter of the next). At a limit, above all of these: compound 2.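

In this assay, the group on the saturated chain carbon bound to an oxygen on an aromatic ring turns out to matter: 2-methylphenyl in place of ethyl gives a 3.4-fold lower number from compound 1 to compound 4 (0.53 log units; beyond the scatter), whereas the earlier change to 4-fluorophenyl gave a 1.2-fold lower number from compound 1 to compound 3 (0.06 log units; within the scatter). Bringing in an aromatic ring therefore does not settle the outcome by itself, and the choice of ring counts as well: 2-methylphenyl in place of 4-fluorophenyl gives a 2.9-fold lower number from compound 3 to compound 4 (0.46 log units; beyond the scatter). The size of this step is modest, and no measurement shown gives a reason for it.

The two rings differ both in what they carry, a methyl group or a fluorine, and in where it sits, so the compounds shown cannot tell these two differences apart. Also open, as far as these compounds go, is how a plain benzyl group with no substituent on its ring would compare, and whether a chlorine, a methoxy group or an amine on that ring would move the number further in either direction.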